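This account rests on a few compounds, and the source may have more. Where it says the series, first, only, none or still open, it means among the compounds named here.

Measured in a functional assay on cells (Erythrocyte, Rattus norvegicus) for inhibition, read by hemolysis, with a stated time of 1 h; on this read-out higher numbers stand for weaker inhibition and lower numbers for stronger inhibition:

compound 1, `COc1ccc(C(=O)/C=C/c2cc(OC)c(OC)cc2OC)cc1`, compound 1 gives 2.18 ug/mL
compound 2, `COc1cc(OC)c(OC)cc1/C=C/C(=O)c1ccc(Cl)c([N+](=O)[O-])c1`, compound 2 gives 2.15 ug/mL
compound 3, `COc1cc(OC)c(C2CC(=O)c3cc(O)ccc3O2)cc1OC`, compound 3 gives 2.14 ug/mL

The three numbers sit on top of one another. Compound 1 holds the highest of the three, but the gap to compound 2 and the gap to compound 3 are both within the scatter of repeated measurements, so no order among the three can be read from these values, and none of them can be called more or less active than another. Within the data shown here, no pair of measured compounds differs in a single place, so no step size is known.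

Compound 4, `COc1cc(OC)c(OC)cc1/C=C/C(=O)c1ccc(Br)cc1`, has not yet been measured in this assay. It differs from compound 1 as follows: bromo in place of methoxy on an aromatic carbon; the change sits on an aromatic carbon of a six-membered aromatic ring of carbon only, para to a large group.

Among the measured compounds shown here, with no measured step in hand and the three known values lying inside one band, the expectation is a step from compound 1 to compound 4 of a 1.0-fold higher number from compound 1 to compound 4 (0.00 log units; within the scatter), that is, none beyond the scatter in either direction. Compound 4 is therefore estimated at 2.2 ug/mL in this assay, within a range of 1.1 ug/mL to 4.4 ug/mL.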

Compound 4, half-maximal inhibitory concentration: 2.3 ug/mL
Compound 4: middle estimate off by 1.0-fold (0.02 log units), on the low side; low and high end bracket the measured number.
By their numbers in this assay, from the lowest: compounds 3, 2, 1 and 4 (each within the scatter of the next).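

In this assay, among these compounds, the change from 4-methoxyphenyl to 4-bromophenyl gives a 1.1-fold higher number from compound 1 to compound 4 (0.02 log units; within the scatter) and is the only step that can be read at a single place. On this aromatic carbon, para to a large group, bromo in place of methoxy leaves the number within the scatter, so this pair shows no difference in the read-out between the two groups. No measured evidence bears on this result, and the data offer no explanation for it.

Going by these compounds, whether an amine, a carboxylic acid or a longer alkoxy chain at this same carbon would also stay within the scatter remains open. With each of the four values within the scatter of the next, the compounds shown do not reveal which structural change, at this place or elsewhere on the shared core, would move the number beyond it.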